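This account rests on a few compounds, and the source may have more. Where it says the series, first, only, none or still open, it means among the compounds named here.

Only a small fraction of a drug-like molecule floats free, and an ADME assay on a cell-free system (plasma, Rattus norvegicus) (on this read-out higher numbers stand for a larger free fraction and lower numbers for a smaller free fraction), puts a number on that share. In this assay, compound 2 (`CC(C)c1ccc(S(C)(=O)=O)cc1C#Cc1cc(Cl)ccc1OCC(=O)O`) gives 0.004. Going by the values given here, the only other measured compound, compound 1 (`CN(C)S(=O)(=O)c1ccc(F)c(C#Cc2cc(Cl)ccc2OCC(=O)O)c1`), gives 0.007. These two numbers lie within the usual scatter of each other, so compound 2 sits level with compound 1, and both show a very small free fraction.

The next molecule is compound 3 (`CS(=O)(=O)c1ccc(F)c(C#Cc2cc(Cl)ccc2OCC(=O)O)c1`), which keeps the core of compound 2 and differs from it in one place: fluoro in place of isopropyl on an aromatic carbon. The swap sits para to a methylsulfonyl group. Among the compounds with values here, no measured pair of compounds differs in just one place, so this expectation has no direct precedent. Compound 1 also carries a fluoro group and gives 0.007, which suggests no large jump. A modest rise is expected, at about the edge of the scatter, and the estimated step is a 2.5-fold higher number from compound 2 to compound 3 (0.40 log units; beyond the scatter). For compound 3 the expected value is 0.01, with an estimated range of 0.005 to 0.02.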

Compound 3, unbound fraction: 0.011
For compound 3 the middle estimate is 1.1-fold (0.04 log units) below the measured one, within the range that was stated.
By their numbers in this assay, from the lowest: compounds 2, 1 and 3 (each within the scatter of the next, the first and the last beyond it).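

In this assay, going by these compounds alone, fluoro in place of isopropyl on this aromatic carbon, para to a methylsulfonyl group, gives a 2.8-fold higher number from compound 2 to compound 3 (0.44 log units; beyond the scatter) and is the only step here that lies beyond the usual scatter, so the free fraction does respond to the group at this position, even though it stays very small in all three compounds. With fluoro held constant, methyl in place of dimethylamino on the sulfonyl sulfur gives a 1.6-fold higher number from compound 1 to compound 3 (0.20 log units; within the scatter) and so cannot be told apart from the spread of repeated measurements, which means this second change shows no clear effect of its own. No measurement shown here accounts for the size of the step from isopropyl to fluoro.

Within the data shown here, only isopropyl and fluoro can be compared at this position so far, so how an amine, a methoxy group or a longer chain would read there remains open. Also open, from the compounds shown here alone, is whether the step from isopropyl to fluoro would keep its size with dimethylamino rather than methyl on the sulfonyl sulfur.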